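Removing a methyl from the triazole nitrogen: expected maximal response

A few compounds are considered here, and "the series" means these few. Any claim that something is new, unique, unknown or untested is made for them only; others in the source may bear on it.

Measured so far:
Compound 1, `Cc1nc(-c2ccccc2NCC2=NCCN2)n(C)n1`: 98%
Compound 2, `CCn1ccc(-c2ccccc2NCC2=NCCN2)n1`: 78%

Of the compounds shown here, two have been tested in a functional assay with Alpha-1A adrenergic receptor (Homo sapiens) as the target, read by calcium flux (a higher number here means a larger maximal response, a lower number a smaller maximal response), a measurement of how large a response a compound can provoke. Compound 1 gives 98%, the higher of the two numbers, and compound 2, with a different five-membered ring on the shared core, gives 78%, a gap that lies beyond the usual scatter. Among the compounds with values here, no pair of measured compounds differs in only one place, so no single-change step can be read from these data.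

Compound 3, `Cc1n[nH]c(-c2ccccc2NCC2=NCCN2)n1`, has not yet been measured. It differs from compound 1 as follows: hydrogen in place of methyl on an aromatic nitrogen. A methyl leaves and a hydrogen enters, on an aromatic nitrogen of the five-membered ring. Because compound 1 gives 98%, a small downward step of a number 10 percentage points lower from compound 1 to compound 3 (within the scatter) is expected, probably within the scatter. Compound 3 is estimated to give 88%, between 65% and 105%.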

Compound 3, largest response reached (reported as maximal response), in percent of the reference or control that the assay uses: 87%
Compound 3: middle estimate off by 1 percentage points, on the high side, and the stated range covers the measured number.
By their numbers in this assay, from the lowest: compounds 2 and 3 (each within the scatter of the next); then compound 1.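

Replacing the methyl on the aromatic nitrogen with hydrogen gives a number 11 percentage points lower from compound 1 to compound 3 (beyond the scatter) in this assay. Within the data shown here, this is the first change in a single place that can be read, and it shows that the maximal response depends on this position only modestly: without the methyl, compound 3 still gives 87%. No measurement here explains why the response falls with this change.

The compounds shown test only methyl and hydrogen at this nitrogen, so it remains open how a longer chain, such as propyl, or a group carrying an amine or a carboxylic acid would affect the response. As far as these compounds go, it is also open whether the same change would give a step of similar size on a different five-membered ring.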